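The source may report more compounds than this note shows. Statements on the series, on what has been measured and on what is new or still open speak of the compounds shown alone.

Compound 1 `Cc1cccc(NC(=O)CN2CCN(c3ccc(Cl)cn3)CC2)c1`: 95 nM
Compound 2 `O=C(CN1CCN(c2ccc(Cl)cn2)CC1)Nc1cccnc1`: 5000 nM

In an assay on HEK293 cells for displacement of a labelled ligand from D(4) dopamine receptor (Homo sapiens), read by scintillation counting, with a stated time of 60 min (a lower number here means a stronger inhibitor, a higher number a weaker inhibitor), compound 2 gives the higher of the two numbers measured, set apart from compound 1 by a 53-fold higher number from compound 1 to compound 2 (1.72 log units; beyond the scatter). Compound 3 `O=C(CN1CCN(c2ccc(Cl)cn2)CC1)Nc1cncnc1` differs from compound 2 by pyrimidin-5-yl in place of pyridin-3-yl on an amide-type nitrogen. For the measured compounds named here, only the step from compound 1 to compound 2 bears on this change, and it was large. Because that step a 53-fold higher number from compound 1 to compound 2 (1.72 log units; beyond the scatter) went against the aza ring, a further aza atom is not expected to recover anything; the expected step is a 1.6-fold higher number from compound 2 to compound 3 (0.20 log units; within the scatter). Compound 3 is therefore estimated at 8000 nM, between 2500 nM and 30000 nM.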

Compound 3, inhibition constant: > 50000 nM
Compound 3 gave a limit, no number; the forecaster's own chance of this, stated with the estimate: 40%; at least 6.2-fold (0.79 log units) between middle value and limit.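

Compound 3 gives no number in this assay, only a limit of the assay: the limit of > 50000 nM in this assay, at which 1 of the 3 values shown sits. Pyrimidin-5-yl in place of pyridin-3-yl on the amide-type nitrogen gives an at least 10-fold higher number from compound 2 to compound 3 (1.00 log units; beyond the scatter), so the second ring nitrogen takes binding down further, and the fall does not stop at compound 2. Against 3-methylphenyl, pyrimidin-5-yl gives an at least 520-fold higher number from compound 1 to compound 3 (2.72 log units; beyond the scatter), so across these three compounds, each added ring nitrogen goes with a weaker inhibitor.

The compounds shown do not separate losing the methyl from gaining a ring nitrogen. Going by these compounds, how an unsubstituted phenyl or a methyl-bearing pyridinyl would read on this nitrogen stays open.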